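The compounds below may be only part of what the source reports. "The series", "measured", "known", "first", "only" and "open" are said of these compounds alone.

Measured in a functional assay on HL-60 cells (Homo sapiens) for cytotoxicity, read by WST assay, with a stated time of 48 h; a lower number here means a stronger inhibitor, a higher number a weaker inhibitor:
- compound 1 `O[C@@H](c1ccccc1)[C@H]1CO[C@H](c2ccccc2)[C@@H](C/C=C/c2cccc(F)c2)C1`: 9170 nM
- compound 2 `O=[N+]([O-])c1cccc(/C=C/C[C@H]2C[C@@H]([C@@H](O)c3ccccc3)CO[C@@H]2c2ccccc2)c1`: 6350 nM
- compound 3 `O[C@@H](c1ccccc1)[C@H]1CO[C@H](c2ccccc2)[C@@H](C/C=C/C2CCCC2)C1`: 9060 nM

Compound 3, at 9060 nM, holds no distinct rank in this set. The steps of a 1.0-fold lower number from compound 1 to compound 3 (0.01 log units; within the scatter) and a 1.4-fold higher number from compound 2 to compound 3 (0.15 log units; within the scatter) both stay within the scatter, so its value cannot be separated from the other two.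

Compound 4 `O=[N+]([O-])c1ccc(/C=C/C[C@H]2C[C@@H]([C@@H](O)c3ccccc3)CO[C@@H]2c2ccccc2)cc1` is the next case, with 4-nitrophenyl in place of cyclopentyl on a double-bonded chain carbon bound to a double-bonded chain carbon.

Among the compounds with values here, three measured steps bear on this change. The closest is a 1.4-fold higher number from compound 2 to compound 3 (0.15 log units; within the scatter), which exchanges a nitrophenyl group for cyclopentyl at the same place. The step of a 1.0-fold lower number from compound 1 to compound 3 (0.01 log units; within the scatter) makes a similar exchange starting from a fluorinated phenyl group, and a 1.4-fold lower number from compound 1 to compound 2 (0.16 log units; within the scatter) exchanges fluoro for nitro on the aromatic ring. All three are small. Within the data shown here, no measured compound carries the 4-nitrophenyl group, so the effect of this particular group remains untested.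

No step beyond the scatter is therefore expected in this assay. The estimated step is a 1.4-fold lower number from compound 3 to compound 4 (0.14 log units; within the scatter), and this expected change stays within the scatter. For compound 4 the estimated value is 6500 nM, with an expected range of 3000 nM to 12000 nM.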

Compound 4, half-maximal inhibitory concentration: 4880 nM
For compound 4 the middle estimate is 1.3-fold (0.12 log units) above the measured one; low and high end bracket the measured number.
By their numbers in this assay, from the lowest: compounds 4, 2, 3 and 1 (each within the scatter of the next).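

In this assay, the step of a 1.9-fold lower number from compound 3 to compound 4 (0.27 log units; within the scatter) replaces cyclopentyl with 4-nitrophenyl on the double-bonded chain carbon, and the step of a 1.9-fold lower number from compound 1 to compound 4 (0.27 log units; within the scatter) replaces 3-fluorophenyl with the same group; these are the largest steps seen so far in the series, yet both remain within the scatter. Within the data shown here, the step of a 1.3-fold lower number from compound 2 to compound 4 (0.11 log units; within the scatter) adds the first comparison of the two nitrophenyl groups at this place and is also within the scatter, so neither the choice between 3-nitrophenyl and 4-nitrophenyl nor the exchange of either for cyclopentyl or 3-fluorophenyl gives a separable change in this read-out across compounds 1 to 4. No supporting measurement is available that would account for these small steps.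

Going by these compounds, whether an amine, a carboxylic acid or a longer chain on the double-bonded chain carbon would give a step beyond the scatter remains open. On these data alone, all four compounds also share the same core, including its hydroxyl group and both unsubstituted phenyl groups, so the contribution of those parts to the cytotoxicity remains unknown.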